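Enlarging the Saturated Amine Ring of Compound 3

This account rests on a few compounds, and the source may have more. Where it says the series, first, only, none or still open, it means among the compounds named here.

Measured compounds:
compound 1 `CC(C(=O)NCc1ccc(C(F)(F)F)nc1Nc1ccccc1)c1ccc(NS(C)(=O)=O)c(F)c1` — 59.6 nM
compound 2 `CC(C(=O)NCc1ccc(C(F)(F)F)nc1Nc1ccc(F)cc1)c1ccc(NS(C)(=O)=O)c(F)c1` — 39.2 nM
compound 3 `CC(C(=O)NCc1ccc(C(F)(F)F)nc1N1CCCC1)c1ccc(NS(C)(=O)=O)c(F)c1` — 0.6 nM

All three share one core and were tested in a functional assay on CHO-K1 cells for antagonist activity at transient receptor potential cation channel subfamily V member 1 (Homo sapiens), read by FLIPR; a lower number here means a stronger inhibitor, a higher number a weaker inhibitor. Compound 3 stands lowest of the three numbers: the step of a 99-fold lower number from compound 1 to compound 3 (2.00 log units; beyond the scatter) and the step of a 65-fold lower number from compound 2 to compound 3 (1.82 log units; beyond the scatter) are both large and beyond the scatter, whereas the step of a 1.5-fold lower number from compound 1 to compound 2 (0.18 log units; within the scatter) lies within it.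

Compound 4 `CC(C(=O)NCc1ccc(C(F)(F)F)nc1N1CCC(c2ccccc2)CC1)c1ccc(NS(C)(=O)=O)c(F)c1` differs from compound 3 in one place: 4-phenylpiperidin-1-yl in place of pyrrolidin-1-yl on an aromatic carbon. For the measured compounds named here, no measured step exchanges one saturated ring amine for another at this position; the two large steps only show that a saturated ring amine here gives a far lower number than an anilino group. The group entering keeps the ring nitrogen attached to the core but adds a second, aromatic ring. From the compounds shown here alone, the expected step of a 5.0-fold higher number from compound 3 to compound 4 (0.70 log units; beyond the scatter) is therefore a moderate rise, because the gain seen in a 99-fold lower number from compound 1 to compound 3 (2.00 log units; beyond the scatter) came from a small ring and a much larger one is untested. Compound 4 is estimated at 3 nM, within a range from 0.5 nM to 20 nM.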

Compound 4, inhibition constant: 0.6 nM
The estimate for compound 4 lay 5.0-fold (0.70 log units) above the measured number; the range from low to high includes it.
By their numbers in this assay, from the lowest: compounds 3 and 4 (each within the scatter of the next); then compounds 2 and 1 (each within the scatter of the next).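

In this assay, the carbon next to the ring nitrogen takes 4-phenylpiperidin-1-yl, with its larger saturated ring and added aromatic ring, as well as it takes pyrrolidin-1-yl, as the step shows: no change at the digits printed from compound 3 to compound 4 (within the scatter). The large gain over the anilino and (4-fluorophenyl)amino groups is therefore not limited to a small saturated ring, and it appears again in a 99-fold lower number from compound 1 to compound 4 (2.00 log units; beyond the scatter) and in a 65-fold lower number from compound 2 to compound 4 (1.82 log units; beyond the scatter). No measurement at hand explains why these two different ring amines give matching numbers.

From the compounds shown here alone, it remains open whether the phenyl ring of compound 4 contributes anything: an unsubstituted piperidin-1-yl group or a morpholin-4-yl group would help separate the saturated ring from the aromatic one. How much larger the group could become, for instance with a benzyl group on the piperidine ring, is also unknown.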